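The source may report more compounds than this note shows. Statements on the series, on what has been measured and on what is new or still open speak of the compounds shown alone.

Measured so far:
compound 1, `COc1cccc(-c2nc(SCC3C[C@](C)(O)CC(=O)O3)[nH]c2-c2cccc(OC)c2)c1`, 570 nM
compound 2, `CC1=CC(=O)OC(CSc2nc(-c3ccccc3)c(-c3ccccc3)[nH]2)C1`, 200 nM
compound 3, `CC1=CC(=O)OC(CSc2nc(-c3ccccc3Cl)c(-c3ccccc3Cl)[nH]2)C1`, 1700 nM

All three were tested in an assay on microsomes from liver for inhibition of sterol O-acyltransferase 1 (Rattus norvegicus); on this read-out higher numbers stand for weaker inhibition and lower numbers for stronger inhibition. Among these three numbers compound 2 gives the lowest one, the strongest inhibition seen here. Compound 1 is nearest to it, and compound 3 is furthest away; both gaps lie beyond the usual scatter of repeated measurements, so compound 2 stands apart from the other two on this read-out.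

Compound 4, `c1ccc(-c2nc(SCC3OCCO3)[nH]c2-c2ccccc2)cc1`, has not been measured yet. It differs from compound 2 in one place: a group of 5 heavy atoms (3 carbon, 2 oxygen; one five-membered non-aromatic ring with 2 hetero atoms) in place of a group of 8 heavy atoms (6 carbon, 2 oxygen; one six-membered non-aromatic ring with 1 hetero atom), on a saturated chain carbon bound to a sulfur. Among the compounds with values here, no measured pair shows what such a change does, so the expectation rests only on the numbers above. Because compound 2 gives 200 nM with the larger ring group in place, and the replacement is the smaller 1,3-dioxolan-2-yl, the step from compound 2 to compound 4 is expected to be a moderate loss, a 4.0-fold higher number from compound 2 to compound 4 (0.60 log units; beyond the scatter), beyond the scatter. Compound 4 is therefore estimated at 800 nM in this assay, within a range from 250 nM to 2500 nM.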

Compound 4, half-maximal inhibitory concentration: 530 nM
Estimate against measurement, compound 4: 1.5-fold (0.18 log units) above; the range from low to high includes it.
By their numbers in this assay, from the lowest: compound 2; then compounds 4 and 1 (each within the scatter of the next); then compound 3.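

Within the data shown here, this is the first pair here that differs in one place only, so this assay now gives a direct reading of the group on a saturated chain carbon bound to a sulfur: the change to 1,3-dioxolan-2-yl gives a 2.7-fold higher number from compound 2 to compound 4 (0.42 log units; beyond the scatter) with the rest of the molecule untouched. The step is modest, so inhibition weakens but does not vanish, and the larger six-membered ring group is not required for inhibition to be measured. Nothing available explains why this change has the effect it does.

As far as these compounds go, whether a carboxylic acid or a plain longer chain, with no ring at all, would be tolerated on this carbon remains open. From the compounds shown here alone, it is also open whether 1,3-dioxolan-2-yl would have a similar effect on the core of compound 3.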